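This account rests on a few compounds, and the source may have more. Where it says the series, first, only, none or still open, it means among the compounds named here.

Measured in a functional assay on NCI-H520 cells (Homo sapiens) for cytotoxicity; a higher number here means a weaker inhibitor of growth, a lower number a stronger inhibitor of growth:
- compound 1 `CSc1ccc(C2=C(c3ccc(F)c(C)c3)C(=O)N3CCCC3C2)cc1`: 500 nM
- compound 2 `CSc1ccc(C2=C(c3ccc(O)cc3)C(=O)N3CCCC3C2)cc1`: > 100000 nM (a limit of the assay, not a number)
- compound 3 `CSc1ccc(C2=C(c3ccc(OCC4CO4)cc3)C(=O)N3CCCC3C2)cc1`: 30 nM

Compound 3 has the lowest number here, and compound 1 is its nearest neighbour, on the higher side. Compound 4 `CSc1ccc(C2=C(c3ccc(SC)cc3)C(=O)N3CCCC3C2)cc1` has methylsulfanyl in place of (oxiran-2-yl)methoxy on an aromatic carbon. Two measured steps change this aryl side of the molecule, an at least 200-fold higher number from compound 1 to compound 2 (2.30 log units; beyond the scatter) and an at least 3300-fold lower number from compound 2 to compound 3 (3.52 log units; beyond the scatter), and both are large. Neither tests methylsulfanyl, so any forecast is loose. Compound 3 alone carries the (oxiran-2-yl)methoxy group, while compound 1 lacks it and gives 500 nM, so a higher number is expected. The expected step is a 10-fold higher number from compound 3 to compound 4 (1.00 log units; beyond the scatter). The estimate for compound 4 is 300 nM, with an estimated range of 40 nM to 3000 nM.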

Compound 4, concentration for 50% growth inhibition: 15000 nM
For compound 4 the middle estimate is 50-fold (1.70 log units) below the measured one, and the stated range ends below it.
By their numbers in this assay, from the lowest: compound 3; then compound 1; then compound 4. At a limit, above all of these: compound 2.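

In this assay, methylsulfanyl is a poor replacement for (oxiran-2-yl)methoxy on this aromatic carbon, giving a 500-fold higher number from compound 3 to compound 4 (2.70 log units; beyond the scatter), and the 4-(methylsulfanyl)phenyl group also falls behind 4-fluoro-3-methylphenyl, with a 30-fold higher number from compound 1 to compound 4 (1.48 log units; beyond the scatter). Even so, methylsulfanyl does better than hydroxy, with an at least 6.6-fold lower number from compound 2 to compound 4 (0.82 log units; beyond the scatter). Compound 2 stands at a limit of the assay, not a number: the limit of > 100000 nM in this assay, at which 1 of the 4 values shown sits.

From the compounds shown here alone, it remains open whether the low number of compound 3 needs the three-membered ring or only a chain on the oxygen. A plain propoxy chain or an amine on this aromatic carbon would help to tell these apart.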